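Adding a hydroxy to compound 1

A few compounds are considered here, and "the series" means these few. Any claim that something is new, unique, unknown or untested is made for them only; others in the source may bear on it.

In a physicochemical assay for lipophilicity, at pH 7.4 (a lower number here means a more polar compound, a higher number a more lipophilic compound), compound 1 (`O=c1[nH]c(Oc2ccccc2)nc2cnccc12`) gives 1.2. This is the middle of three numbers: compound 3 (`O=c1[nH]c(Oc2cccnc2)nc2cnccc12`) lies lower at -0.2, and compound 2 (`O=c1[nH]c(OC2CCCCC2)nc2cnccc12`) lies higher at 3.7. Compound 4 (`O=c1[nH]c(Oc2cccc(O)c2)nc2cnccc12`) differs from compound 1 by one change, (hydroxy in place of hydrogen on an aromatic carbon), with hydroxy in place of hydrogen on an aromatic carbon, meta to a large group. Among the compounds with values here, no measured step makes this exact change. The closest guide is the swap to pyridin-3-yl, which keeps an aromatic ring: a number 1.40 log units lower from compound 1 to compound 3 (beyond the scatter). The swap to cyclohexyl is a different kind of change: a number 2.50 log units higher from compound 1 to compound 2 (beyond the scatter). Both replace a whole ring, whereas here one group replaces a hydrogen, so a smaller downward step in this assay is expected: a number 0.60 log units lower from compound 1 to compound 4 (beyond the scatter). For compound 4 the estimated value is 0.6, with an expected range from 0.1 to 1.1.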

Compound 4, distribution coefficient: 0.3
Compound 4: middle estimate off by 0.30 log units, on the high side, and the stated range covers the measured number.
By their numbers in this assay, from the lowest: compound 3; then compound 4; then compound 1; then compound 2.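

With hydroxy in place of hydrogen on an aromatic carbon, meta to a large group, this assay shows a number 0.90 log units lower from compound 1 to compound 4 (beyond the scatter). Within the data shown here, the earlier steps each replaced a whole ring, so this is the first to show what a single group does while the phenyl ring stays in place. No measurement shown explains the size of this step. As far as these compounds go, it remains open whether a methoxy or an amine at this same place would give a similar step. From the compounds shown here alone, the effect of a hydroxy elsewhere on the ring also remains open.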